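A few compounds are considered here, and "the series" means these few. Any claim that something is new, unique, unknown or untested is made for them only; others in the source may bear on it.

Measured so far:
compound 1 `COC(=O)N1CCN([C@H]2CC[C@H](Nc3ncnn4ccc([C@H](C)CC(N)=O)c34)CC2)CC1` — 0.37
compound 2 `CC(=O)N1CCN([C@H]2CC[C@H](Nc3ncnn4ccc(C(C)C)c34)CC2)CC1` — 0.28

In an ADME assay on the whole organism (plasma, Rattus norvegicus, strain Han Wistar) for protein binding, using equilibrium dialysis (on this read-out lower numbers stand for a smaller free fraction and higher numbers for a larger free fraction), compound 1 gives 0.37 and compound 2 gives 0.28; the two numbers sit within the usual scatter of each other, so compound 2 cannot be placed apart from compound 1 in this assay. Within the data shown here, no single-point step between measured compounds exists in the set.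

Compound 3 `CC(=O)N1CCN([C@H]2CC[C@H](Nc3ncnn4ccc(C5CCOCC5)c34)CC2)CC1` is not yet measured. It differs from compound 2 by oxan-4-yl in place of isopropyl on an aromatic carbon. Among the measured compounds shown here, with only two close values as a base, the expected step of a 1.4-fold higher number from compound 2 to compound 3 (0.15 log units; within the scatter) is small, tending toward a larger free fraction. The estimate for compound 3 in this assay is 0.4, expected between 0.28 and 0.57.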

Compound 3, unbound fraction in the Rattus norvegicus assay: 0.54
Compound 3: middle estimate off by 1.4-fold (0.13 log units), on the low side; the range from low to high includes it.
By their numbers in the Rattus norvegicus assay, from the lowest: compounds 2, 1 and 3 (each within the scatter of the next).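

Among these compounds, the first single-place step at this aromatic carbon, in the Rattus norvegicus assay, is a 1.9-fold higher number from compound 2 to compound 3 (0.29 log units; within the scatter), so oxan-4-yl and isopropyl cannot be told apart here. In a physicochemical assay for solubility, in phosphate buffer, at pH 7.4 (on this read-out lower numbers stand for lower solubility and higher numbers for higher solubility), compound 2 gives > 952000 nM, which is a limit of the assay. In the physicochemical assay compound 3 gives > 1000000 nM, also a limit, so the step on this read-out cannot be read.

Still open, on these data alone, is whether cyclohexyl at this aromatic carbon would separate the contribution of the ring from that of its oxygen. Also open, as far as these compounds go, is whether an amine or a carboxylic acid there would give a step beyond the scatter in the Rattus norvegicus assay.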